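Aryl swap on the hydroxypropyl chain of the shared core

The source may report more compounds than this note shows. Statements on the series, on what has been measured and on what is new or still open speak of the compounds shown alone.

Compound 1 `OC(CCn1nc2c(Br)c(Br)c(Br)c(Br)c2n1)c1cccc(Br)c1`: 0%
Compound 2 `OC(CCn1nc2c(Br)c(Br)c(Br)c(Br)c2n1)c1ccc(F)cc1`: 0%

Two compounds sharing a tetrabrominated core with a hydroxypropyl linker have been measured in a functional assay on CCRF-CEM cells (Homo sapiens) for antiproliferative activity, read by MTT assay, with a stated time of 24 h, tested at 100 uM; a higher number here means a weaker effect of the compound at the concentration tested, a lower number a stronger effect. Compound 1 gives 0%, and compound 2 gives 0%. The single step between them, no change at the digits printed from compound 1 to compound 2 (within the scatter), therefore shows that exchanging the aryl group at the carbinol position left the read-out unchanged within the scatter, and compound 2 stands level with compound 1 at the digits shown.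

Compound 3 `COc1cccc(C(O)CCn2nc3c(Br)c(Br)c(Br)c(Br)c3n2)c1` has not yet been measured. It differs from compound 2 only at the same carbinol position: 3-methoxyphenyl in place of 4-fluorophenyl on a saturated chain carbon bound to an oxygen on a saturated carbon and a saturated chain carbon. The 4-fluorophenyl leaves and a 3-methoxyphenyl enters, which adds one hydrogen-bond acceptor and one heavy atom but keeps the aromatic ring and the rest of the molecule intact.

Within the data shown here, the only step that bears on this change, from compound 1 to compound 2, was flat, so a further aryl replacement at that position is expected to give a step of no change at the digits printed from compound 2 to compound 3 (within the scatter) that stays within the scatter. Compound 3 is estimated at 0%, with a range from 0% to 12%.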

Compound 3, a percentage reported as activity, at one concentration (the size of the read-out at that concentration, not a potency): 48%
Estimate against measurement, compound 3: 48 percentage points below, and the stated range ends below it.
By their numbers in this assay, from the lowest: compounds 1 and 2 (each within the scatter of the next); then compound 3.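

The position on the saturated chain carbon bound to an oxygen is not indifferent to its aryl group in this assay: 3-methoxyphenyl in place of 4-fluorophenyl gives a number 48 percentage points higher from compound 2 to compound 3 (beyond the scatter), so the flat step between the first two compounds does not extend to every aryl group, and the higher number marks a weaker effect at the concentration tested. The comparison with the 3-bromophenyl compound narrows this further, as methoxy in place of bromo on an aromatic carbon gives a number 48 percentage points higher from compound 1 to compound 3 (beyond the scatter), which shows that the substituent matters even when the ring position stays the same. No measurement is available that would explain this loss of effect.

The three compounds do not tell whether the loss belongs to the methoxy group alone or would also appear with a 3-hydroxyphenyl, a 3-ethoxyphenyl or a 3-aminophenyl at this place. They also leave open whether a 4-methoxyphenyl would behave like compound 3 or return to the level of compound 2.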